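Anilino in place of hydroxy: expected effect on growth inhibition

A few compounds are considered here, and "the series" means these few. Any claim that something is new, unique, unknown or untested is made for them only; others in the source may bear on it.

In a functional assay on Bel-7402 cells (Homo sapiens) for inhibition, read by MTT assay, with a stated time of 24 h, tested at 100 ug/mL (on this read-out higher numbers stand for more inhibition of growth at the one concentration tested and lower numbers for less inhibition of growth), compound 1 `CC(=O)SCCC(CCCCC(=O)O)SC(C)=O` gives 8.35% and compound 2 `Cc1cccc(NC(=O)CCCCC(S)CCS)c1` gives 7.08%. Among the compounds with values here, these two values lie within the scatter of each other, so compound 1 stands level with the only other measured compound. Compound 3 `CC(=O)SCCC(CCCCC(=O)Nc1ccccc1)SC(C)=O` has not yet been measured. It differs from compound 1 by anilino in place of hydroxy on a carbonyl carbon. Within the data shown here, no measured pair differing in one place is available, so the data give no direct guide to this change. With compound 2 at 7.08%, the measured values in this assay give no reason to expect a shift beyond the scatter. The expected change is a number 1.7 percentage points higher from compound 1 to compound 3 (within the scatter), and no direction is firmly expected. For compound 3 the estimated value is 10%, with an expected range from 2% to 22%.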

Compound 3, percent growth inhibition at one concentration: 14.1%
Compound 3: middle estimate off by 4.1 percentage points, on the low side, within the range that was stated.
By their numbers in this assay, from the lowest: compounds 2, 1 and 3 (each within the scatter of the next).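

Anilino in place of hydroxy on a carbonyl carbon is the first single-place step in the series, and in this assay it gives a number 5.8 percentage points higher from compound 1 to compound 3 (within the scatter) at this saturated-chain carbonyl. The free hydroxy can therefore give way to anilino, with its six-membered aromatic ring and larger heavy-atom count, without a shift beyond the usual scatter on this read-out. No measurement at hand accounts for the size of this step.

Still open, from the compounds shown here alone, is whether another group on the same carbonyl carbon, such as benzylamino, morpholino or methoxy, would move growth inhibition beyond the scatter. Also open, going by these compounds, is whether a chloro or methoxy group on the anilino ring would do so with the rest of compound 3 unchanged.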